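A Bromo Substituent Added to Compound 2

The source may report more compounds than this note shows. Statements on the series, on what has been measured and on what is new or still open speak of the compounds shown alone.

Compound 1, `COc1cc2c(Oc3ccc(NC(=O)c4nn(-c5ccccc5Br)c(=O)c5ccccc45)cc3F)ccnc2cc1OCCCN1CCCC1`: 410 nM
Compound 2, `COc1cc2c(Oc3ccc(NC(=O)c4nn(-c5ccccc5)c(=O)c5ccccc45)cc3F)ccnc2cc1OCCCN1CCC(C)CC1`: 580 nM

Both numbers come from a functional assay on MKN-45 cells (Homo sapiens) for cytotoxicity, read by MTT assay, with a stated time of 72 h; a lower number here means a stronger inhibitor, a higher number a weaker inhibitor. Compound 2 stands at the higher of the two, though its gap to compound 1 lies within the scatter. Compound 3, `COc1cc2c(Oc3ccc(NC(=O)c4nn(-c5ccccc5Br)c(=O)c5ccccc45)cc3F)ccnc2cc1OCCCN1CCC(C)CC1`, differs from compound 2 in one place: bromo in place of hydrogen on an aromatic carbon. Among the compounds with values here, no measured pair isolates this change, so no measured step for it exists. Compound 1 already carries the same bromo group and gives 410 nM, close to compound 2. Compound 3 is thus expected to give about 450 nM in this assay, between 200 nM and 1000 nM. That estimate means an expected step of a 1.3-fold lower number from compound 2 to compound 3 (0.11 log units; within the scatter), not beyond the scatter.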

Compound 3, half-maximal inhibitory concentration: 510 nM
The estimate for compound 3 lay 1.1-fold (0.05 log units) below the measured number, within the range that was stated.
By their numbers in this assay, from the lowest: compounds 1, 3 and 2 (each within the scatter of the next).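

In this assay, the change from phenyl to 2-bromophenyl now has a measured step of its own (a 1.1-fold lower number from compound 2 to compound 3 (0.06 log units; within the scatter)), and that step stays within the scatter. Putting 4-methylpiperidin-1-yl in place of pyrrolidin-1-yl, with the bromo group present on both compounds, also stays within the scatter (a 1.2-fold higher number from compound 1 to compound 3 (0.09 log units; within the scatter)). Nothing available here bears on a cause for either step. Still open, as far as these compounds go, is whether a chloro group, a methoxy group or an amine on the same aromatic carbon would also leave the number within the scatter.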